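This account rests on a few compounds, and the source may have more. Where it says the series, first, only, none or still open, it means among the compounds named here.

Measured compounds in an assay on CHO cells for displacement of a labelled ligand from adenosine receptor A1 (Homo sapiens), read by scintillation counting, with a stated time of 60 min, tested at 10 uM; a higher number here means more inhibition at the concentration tested (going by the name of the read-out), a lower number less inhibition:
compound 1 `CNC(=O)[C@@]12C[C@@H]1[C@@H](n1cnc3c(NC)nc(C#Cc4ccc(-c5ccccc5)cc4)nc31)[C@H](O)[C@@H]2O` gives 18%
compound 2 `CNC(=O)[C@@]12C[C@@H]1[C@@H](n1cnc3c(NC)nc(C#Cc4ccccc4F)nc31)[C@H](O)[C@@H]2O` gives 20%
compound 3 `CNC(=O)[C@@]12C[C@@H]1[C@@H](n1cnc3c(NC)nc(C#Cc4ccc(F)cc4)nc31)[C@H](O)[C@@H]2O` gives 27%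

Going by the values given here, compound 3 holds the highest of the three numbers, but its nearest neighbour is compound 2, with a number 7 percentage points higher from compound 2 to compound 3 (within the scatter), and the furthest is compound 1, with a number 9 percentage points higher from compound 1 to compound 3 (within the scatter); both gaps lie within the scatter, so no compound can be set apart from the others on these data. Likewise a number 2 percentage points higher from compound 1 to compound 2 (within the scatter) shows no real movement.

Compound 4 `CNC(=O)[C@@]12C[C@@H]1[C@@H](n1cnc3c(NC)nc(C#Cc4ccccc4OC)nc31)[C@H](O)[C@@H]2O` is not yet measured. It differs from compound 3 as follows: 2-methoxyphenyl in place of 4-fluorophenyl on a triple-bonded carbon. Among the compounds with values here, the steps that bear on this are the two swaps of the aryl group on the triple-bonded carbon, compound 1 to compound 3 and compound 2 to compound 3, neither of which moved the number beyond the scatter. Within the data shown here, the shift of the substituent around the ring from compound 2 to compound 3 is the closest precedent and was small. Among the measured compounds shown here, no step supports a change beyond the scatter, so compound 4 is expected to land near compound 3, with an estimated step of a number 5 percentage points lower from compound 3 to compound 4 (within the scatter). For compound 4 the estimate in this assay is 22%, within a range of 8% to 38%.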

Compound 4, a percentage reported as inhibition, at one concentration (the size of the read-out at that concentration, not a potency): 12%
Beside the measured number, compound 4's estimate is 10 percentage points above it; the measured number falls inside the stated range.
By their numbers in this assay, from the lowest: compounds 4, 1, 2 and 3 (each within the scatter of the next, the first and the last beyond it).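

In this assay the group on the triple-bonded carbon now gives its first step beyond the scatter, with a number 15 percentage points lower from compound 3 to compound 4 (beyond the scatter), on going from 4-fluorophenyl to 2-methoxyphenyl. The change is not large across the series, since a number 8 percentage points lower from compound 2 to compound 4 (within the scatter) and a number 6 percentage points lower from compound 1 to compound 4 (within the scatter) both stay within the scatter, so compound 4 is set apart from compound 3 only. No supporting measurement is available to explain this step.

4-Methoxyphenyl on the triple-bonded carbon would be needed to tell whether the step follows the methoxy group itself or the place it holds on the ring. As far as these compounds go, how an amine or a carboxylic acid on that phenyl ring would read in this assay also stays open.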